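A Methyl on the Amide-Type Nitrogen in Two Series

A few compounds are considered here, and "the series" means these few. Any claim that something is new, unique, unknown or untested is made for them only; others in the source may bear on it.

Compound 1 `COc1ccc(Cl)cc1C(C)NC(=O)N(C)S(=O)(=O)c1ccc(Cl)cc1` gives 20000 nM in a functional assay on thoracic aorta (Rattus norvegicus, strain Wistar), with a stated time of 15 min; a higher number here means that more compound is needed for the effect, a lower number that less compound is needed.
Compound 2 `COc1ccc(Cl)cc1C(C)NC(=O)NS(=O)(=O)c1ccc(Cl)cc1` gives only a limit of this assay, > 300000 nM.
Compound 3 `CCOc1ccc(Br)cc1C(C)NC(=O)NS(=O)(=O)c1ccccc1` likewise gives only a limit of this assay, > 300000 nM.

Compound 1 and compound 2 share a core and differ in one place: methyl in place of hydrogen on an amide-type nitrogen. This change made a step of an at least 15-fold lower number from compound 2 to compound 1 (1.17 log units; beyond the scatter) in this assay, so the methyl compound needs far less substance for the effect than its hydrogen counterpart.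

Compound 4 `CCOc1ccc(Br)cc1C(C)NC(=O)N(C)S(=O)(=O)c1ccccc1` is not yet measured. It stands to compound 3 as compound 1 stands to compound 2: methyl in place of hydrogen on an amide-type nitrogen, the same change at the same place. How the core of compound 3 differs from that of compound 2 is not broken down here. Both hydrogen compounds rest at the limit of > 300000 nM in this assay, at which 2 of the 3 values shown sit.

For compound 4 a step of about an at least 7.5-fold lower number from compound 3 to compound 4 (0.87 log units; beyond the scatter) from compound 3 is expected in this assay, resting on the measured step from compound 2 to compound 1. Compound 4 is therefore estimated at 40000 nM, within roughly 10000 nM to 300000 nM, though a limit remains possible.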

Compound 4, half-maximal effective concentration: 19800 nM
The estimate for compound 4 lay 2.0-fold (0.31 log units) above the measured number; low and high end bracket the measured number.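

The change of hydrogen to methyl on the amide-type nitrogen, whose other neighbours are the carbonyl carbon and the sulfonyl sulfur, lowers the number again in this assay, with an at least 15-fold lower number from compound 3 to compound 4 (1.18 log units; beyond the scatter). This shows that the direction of the change carries from one core to a second one, but it does not fix the size of the step on either core, and two cores make no rule for the whole series: the same change on two cores in this assay, an at least 15-fold lower number (1.17 log units; beyond the scatter) from compound 2 to compound 1 and an at least 15-fold lower number (1.18 log units; beyond the scatter) from compound 3 to compound 4; the limit leaves it open whether they differ. The hydrogen compounds therefore offer only a limit as a starting point, not a true number: the limit of > 300000 nM in this assay, at which 2 of the 4 values shown sit.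

The compounds shown leave open whether a group other than methyl on this nitrogen, such as ethyl or a longer chain, would give a similar step. They also leave open how large the step from hydrogen to methyl would be on a core whose hydrogen compound gives a true number rather than a limit.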